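Removing the Fluoro Group from Compound 2

The compounds below may be only part of what the source reports. "The series", "measured", "known", "first", "only" and "open" are said of these compounds alone.

Two compounds share one core. Compound 1 `CC(C)n1c(/C=C2/C(=O)Nc3ccc(Br)cc32)nc2ccccc21` gives 12400 nM in a functional assay on HGC cells (Homo sapiens) for cytotoxicity, read by MTT assay, with a stated time of 48 h; a higher number here means a weaker inhibitor, a lower number a stronger inhibitor. Compound 2 `CCn1c(/C=C2/C(=O)Nc3ccc(F)cc32)nc2ccccc21` reaches only a limit of this assay, > 50000 nM, so it sits at the limit of > 50000 nM in this assay, at which 1 of the 2 values shown sits. Compound 3 `CCn1c(/C=C2/C(=O)Nc3ccccc32)nc2ccccc21` differs from compound 2 in a single change, (hydrogen in place of fluoro on an aromatic carbon). Among the measured compounds shown here, no measured pair shows what this change does here, so the step expected in this assay, a number no higher from compound 2 to compound 3 (the limit leaves the size open), is small and within the usual scatter, in no clear direction. Compound 3 is therefore expected to give about 50000 nM, between 20000 nM and 120000 nM, quite possibly again only a limit.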

Compound 3, half-maximal inhibitory concentration: > 50000 nM
Compound 3 was reported as a limit; the forecaster's own chance of this, stated with the estimate: 60%; the middle value sits exactly at the limit.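

Compound 2 and compound 3 both reach only a limit in this assay, so no step can be read between them: the limit of > 50000 nM in this assay, at which 2 of the 3 values shown sit.

Going by these compounds, what hydrogen in place of fluoro does in this assay stays open, since neither compound gives a number there.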